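Working notes: two limits measured, one compound pending

A few compounds are considered here, and "the series" means these few. Any claim that something is new, unique, unknown or untested is made for them only; others in the source may bear on it.

Measured so far:
compound 1 `COc1ccc(C(=O)/C=C/c2cccc(F)c2)c2c1C=CC(C)(C)O2` — > 10000 nM
compound 2 `COc1ccc(C(=O)/C=C/c2ccc(OC)c(OC)c2OC)c2c1C=CC(C)(C)O2` — > 10000 nM

In a functional assay on SK-OV-3 cells (Homo sapiens) for antiproliferative activity, read by MTT assay, with a stated time of 24 h (a lower number here means a stronger inhibitor, a higher number a weaker inhibitor), compound 1 gives > 10000 nM, which is a limit of the assay rather than a number. Compound 2 likewise gives > 10000 nM, again a limit. Both values sit at the limit of > 10000 nM in this assay, at which 2 of the 2 values shown sit, so compound 1 stands nowhere in particular on the numbers shown: the two values are both limits, and no step between measured compounds can be counted from them.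

Compound 3 `COc1ccc(C(=O)/C=C/c2cc(Cl)ccc2O)c2c1C=CC(C)(C)O2` is the next to be measured in this assay. It differs from compound 1 by 5-chloro-2-hydroxyphenyl in place of 3-fluorophenyl on a double-bonded chain carbon bound to a double-bonded chain carbon. With both measured values at the limit, the step from compound 1 to compound 3 cannot be anchored on data; the expectation is a step of no more than modest size downward, with a fair chance the assay again reports only a limit. Compound 3 is expected to give 8000 nM, within 2000 nM to 30000 nM, an estimated step of an at least 1.2-fold lower number from compound 1 to compound 3 (0.09 log units; that floor lies within the scatter).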

Compound 3, half-maximal inhibitory concentration: 6270 nM
Compound 3: middle estimate off by 1.3-fold (0.11 log units), on the high side; measured number inside the range.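

In this assay, for the compounds shown here, compound 3 gives 6270 nM, the first number that is not a limit, so this position can carry a group that brings the read-out within the measurable range. On these data alone, the change of 3-fluorophenyl to 5-chloro-2-hydroxyphenyl, on a double-bonded chain carbon bound to a double-bonded chain carbon, amounts to an at least 1.5-fold lower number from compound 1 to compound 3 (0.20 log units; that floor lies within the scatter); only this floor can be stated, and the true size of the step remains unknown. Any comparison within the series therefore stays narrow, and the values shown offer only one anchor beyond: the limit of > 10000 nM in this assay, at which 2 of the 3 values shown sit.

The compounds shown do not separate the contribution of the chlorine from that of the hydroxyl within 5-chloro-2-hydroxyphenyl. As far as these compounds go, how an amine or a carboxylic acid at this position would read in this assay also remains open.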